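A methyl added twice on an aromatic carbon

The source may report more compounds than this note shows. Statements on the series, on what has been measured and on what is new or still open speak of the compounds shown alone.

Compound 1 `CC(=O)NCC#CCn1ccnc1` and compound 2 `CC(=O)NCC#CCn1cncc1C` share one core; compound 3 `CN(C)C(=O)N(C)CC#CCn1ccnc1` and compound 4 `Cc1cncn1CC#CCN(C)C(=O)N(C)C` share another, and the difference between the two cores is not broken down here. In a functional assay on the whole organism for antagonist activity, with Mus musculus as the target (on this read-out lower numbers stand for an effect already at smaller amounts and higher numbers for an effect only at larger amounts of compound), compound 1 gives only a limit of the assay, > 100 mg/kg. Compound 2 also gives only a limit, > 100 mg/kg. The change between them is methyl in place of hydrogen on an aromatic carbon, and the step that the two limits leave unreadable from compound 1 to compound 2 cannot be read because of the limit of > 100 mg/kg in this assay, at which 3 of the 3 values shown sit. In this assay compound 3 gives only a limit as well, > 100 mg/kg. Compound 4 carries the same kind of change, (methyl in place of hydrogen on an aromatic carbon), the place differing only in that the ring atom bears a large group rather than a group of 8 heavy atoms. For compound 4 the expected step that the limit leaves unreadable from compound 3 to compound 4 rests on the unreadable a step that the two limits leave unreadable from compound 1 to compound 2. Compound 4 is therefore expected to give about 150 mg/kg, between 60 mg/kg and 400 mg/kg, most likely again only a limit.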

Compound 4, dose for half-maximal effect: > 100 mg/kg
Compound 4: no number, only a limit; the forecaster's own chance of this, stated with the estimate: 85%; the middle value is on the limit's open side.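

The step from compound 3 to compound 4 cannot be read, because both compounds give only a limit: the limit of > 100 mg/kg in this assay, at which 4 of the 4 values shown sit.

The compounds shown leave open whether methyl in place of hydrogen on the aromatic carbon changes the dose needed in this assay, on either core.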